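The compounds below may be only part of what the source reports. "The series", "measured", "known", "first", "only" and "open" are said of these compounds alone.

Measured in an assay on isolated protein for displacement of a labelled ligand from metabotropic glutamate receptor 5 (Homo sapiens), with a stated time of 60 min, tested at 1 uM; on this read-out lower numbers stand for less inhibition and higher numbers for more inhibition at the one concentration tested (going by the name of the read-out):
compound 1 `COc1ccc2ncc(S(=O)(=O)c3ccc(C)cc3)c(N3CCC(C)CC3)c2c1` gives 90%
compound 2 `Cc1ccc(S(=O)(=O)c2cnc3ccc(Cl)cc3c2N2CCC(C)CC2)cc1` gives 95%
compound 3 `Cc1ccc(S(=O)(=O)c2cnc3ccc(C)cc3c2N2CCC(C)CC2)cc1` gives 82%

On these numbers compound 1 stands close to both neighbours: a number 5 percentage points higher from compound 1 to compound 2 (within the scatter) and a number 8 percentage points lower from compound 1 to compound 3 (within the scatter) are each within the scatter, and only a number 13 percentage points lower from compound 2 to compound 3 (beyond the scatter) reaches beyond it. All three measured changes sit on an aromatic carbon of the shared core.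

Compound 4 `COc1ccc2ncc(S(=O)(=O)c3cc(C)cc(C)c3)c(N3CCC(C)CC3)c2c1` differs from compound 1 elsewhere: 3,5-dimethylphenyl in place of 4-methylphenyl on a sulfonyl sulfur. Going by the values given here, no measured step touches this sulfonyl-bound ring, so nothing bears directly on the change. The three measured values are all high and lie near one another, so the expectation for compound 4 in this assay is no step beyond the scatter, a number 5 percentage points lower from compound 1 to compound 4 (within the scatter). Compound 4 is estimated at 85%, with a range from 65% to 97%.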

Compound 4, a percentage reported as inhibition, at one concentration (the size of the read-out at that concentration, not a potency): 79%
Compound 4: middle estimate off by 6 percentage points, on the high side; the measured number falls inside the stated range.
By their numbers in this assay, from the lowest: compounds 4, 3, 1 and 2 (each within the scatter of the next, the first and the last beyond it).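

In this assay, the sulfonyl-bound ring responds to substitution: 3,5-dimethylphenyl in place of 4-methylphenyl gives a number 11 percentage points lower from compound 1 to compound 4 (beyond the scatter), though the step is modest. This is the first change shown away from the aromatic carbon varied in compounds 1, 2 and 3. It replaces 7 heavy atoms with 8 and also alters the methyl pattern, and a single pair cannot separate these two differences.

From the compounds shown here alone, whether phenyl, 4-chlorophenyl or 4-methoxyphenyl on the sulfonyl sulfur would hold the number high remains open. No data here explain the step.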